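Para-trifluoromethyl aniline variant of the quinazoline-sulfonamide series

The source may hold more compounds than are shown below. What is called first, only, known or untested is meant among the compounds shown, and "the series" means these compounds.

Compound 1 `COc1cc2ncnc(Nc3cccc(F)c3)c2cc1OCCCCC(=O)Nc1ccc(S(N)(=O)=O)cc1` is read in a functional assay on A549 cells (Homo sapiens) for antiproliferative activity, read by MTT assay, with a stated time of 72 h (on this read-out higher numbers stand for weaker inhibition and lower numbers for stronger inhibition), only as a limit, > 40000 nM, with no number inside the range of the assay. Compound 2 `COc1cc2ncnc(Nc3ccc(F)c(Br)c3)c2cc1OCCCCC(=O)Nc1ccc(S(N)(=O)=O)cc1` gives 16000 nM in this assay. Compound 3 `COc1cc2ncnc(Nc3cc(F)c(F)c(F)c3)c2cc1OCCCCC(=O)Nc1ccc(S(N)(=O)=O)cc1` also sits at the limit, > 40000 nM. Compound 1 thus stands at the top of the measured values, because of the limit of > 40000 nM in this assay, at which 2 of the 3 values shown sit. Compound 4 `COc1cc2ncnc(Nc3ccc(C(F)(F)F)cc3)c2cc1OCCCCC(=O)Nc1ccc(S(N)(=O)=O)cc1` differs from compound 1 in one place: 4-(trifluoromethyl)phenyl in place of 3-fluorophenyl on a nitrogen on an aromatic ring. Going by the values given here, the steps that bear on this change are an at least 2.5-fold lower number from compound 1 to compound 2 (0.39 log units; beyond the scatter) and an at least 2.5-fold higher number from compound 2 to compound 3 (0.39 log units; beyond the scatter); the step that the two limits leave unreadable from compound 1 to compound 3 gives no size. Among the compounds with values here, no measured step covers 4-(trifluoromethyl)phenyl itself, so the expectation stays near the limit. For compound 4 the estimated value in this assay is 35000 nM, within 10000 nM to 100000 nM, which is an expected step of an at least 1.1-fold lower number from compound 1 to compound 4 (0.05 log units; that floor lies within the scatter).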

Compound 4, half-maximal inhibitory concentration: 14800 nM
Beside the measured number, compound 4's estimate is 2.4-fold (0.37 log units) above it, within the range that was stated.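

A 4-(trifluoromethyl)phenyl on the nitrogen gives a number inside the assay range without any bromine, with an at least 2.7-fold lower number from compound 1 to compound 4 (0.43 log units; beyond the scatter) and an at least 2.7-fold lower number from compound 3 to compound 4 (0.43 log units; beyond the scatter) in this assay. Against the 3-bromo-4-fluorophenyl group there is a 1.1-fold lower number from compound 2 to compound 4 (0.03 log units; within the scatter), so compound 2 and compound 4 are not separated here. Compound 1 and compound 3 remain limits, not numbers: the limit of > 40000 nM in this assay, at which 2 of the 4 values shown sit.

Open, going by these compounds, is whether a 4-methoxyphenyl or 4-chlorophenyl on this nitrogen reads the same. A plain phenyl would test whether the trifluoromethyl group itself carries the step.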